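A Methoxy for a Methyl on Two Different Cores

A few compounds are considered here, and "the series" means these few. Any claim that something is new, unique, unknown or untested is made for them only; others in the source may bear on it.

Compound 1 `COn1c(-c2ccc(C)cc2)c(C=O)c2cc(C#N)c(C#N)cc21` and compound 2 `COc1ccc(-c2c(C=O)c3cc(C#N)c(C#N)cc3n2OC)cc1` share one core and differ only by methoxy in place of methyl on an aromatic carbon. In an assay on isolated protein for inhibition of Amine oxidase [flavin-containing] A (Homo sapiens), read by fluorescence and spectrophotometry, with a stated time of 20 min (a lower number here means a stronger inhibitor, a higher number a weaker inhibitor), compound 1 gives 405 nM, and compound 2 gives 147 nM; the change brought a 2.8-fold lower number from compound 1 to compound 2 (0.44 log units; beyond the scatter).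

Compound 3 `Cc1ccc(-c2cc3cc(C(=O)O)c(C(=O)O)cc3n2O)cc1` carries a second core; the difference between the two cores is not broken down here. Compound 3 reaches only (the limit of > 100000 nM in this assay, at which 1 of the 3 values shown sits), so its value of > 100000 nM in this assay is a limit and not a number.

Compound 4 `COc1ccc(-c2cc3cc(C(=O)O)c(C(=O)O)cc3n2O)cc1` is to be measured; it differs from compound 3 by methoxy in place of methyl on an aromatic carbon, the same change as between compound 1 and compound 2. For compound 4 the step that the limit leaves unreadable from compound 3 to compound 4 is expected to stay near the limit, because compound 3 itself sits at the limit of > 100000 nM in this assay, at which 1 of the 3 values shown sits, and the measured step was only modest. Compound 4 is therefore estimated at 150000 nM, most likely again reported only as a limit.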

Compound 4, half-maximal inhibitory concentration: > 100000 nM
Compound 4: no number, only a limit (the forecaster's own chance of this, stated with the estimate: 80%); the middle value is on the limit's open side.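

No step from methyl to methoxy can be read between compound 3 and compound 4, since both results are limits and not numbers: the limit of > 100000 nM in this assay, at which 2 of the 4 values shown sit.

On these data alone, whether this change does anything on the core of compound 3 stays open.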